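Aryl sulfone variation on a shared core at mGlu5

This account rests on a few compounds, and the source may have more. Where it says the series, first, only, none or still open, it means among the compounds named here.

Measured compounds:
compound 1, `CC1CCN(c2c(S(=O)(=O)c3cc(F)cc(F)c3)cnc3cc(Cl)ccc23)CC1`, 94%
compound 2, `CC1CCN(c2c(S(=O)(=O)c3cccc(Cl)c3)cnc3cc(Cl)ccc23)CC1`, 92%
compound 3, `Cc1ccc(S(=O)(=O)c2cnc3cc(Cl)ccc3c2N2CCC(C)CC2)cc1F`, 85%

In an assay on isolated protein for displacement of a labelled ligand from metabotropic glutamate receptor 5 (Homo sapiens), with a stated time of 60 min, tested at 1 uM (a lower number here means less inhibition, a higher number more inhibition at the concentration tested (going by the name of the read-out)), the three measured compounds differ only in the aryl group on the sulfonyl sulfur. Compound 3 returns the lowest of the three numbers, but its distance to the others stays inside the scatter: a number 9 percentage points lower from compound 1 to compound 3 (within the scatter) and a number 7 percentage points lower from compound 2 to compound 3 (within the scatter), so the three values cannot be ranked. The other step among them, a number 2 percentage points lower from compound 1 to compound 2 (within the scatter), is likewise within the scatter.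

Compound 4, `COc1cccc(S(=O)(=O)c2cnc3cc(Cl)ccc3c2N2CCC(C)CC2)c1`, is not yet measured. It differs from compound 3 in one place: 3-methoxyphenyl in place of 3-fluoro-4-methylphenyl on a sulfonyl sulfur.

All three measured steps bear on this change, since each swaps one aryl group on the sulfonyl sulfur for another, and none of them moved this assay beyond the scatter. The aryl group entering compound 4 is of the same size as the one leaving, so compound 4 is expected to stay close to compound 3, with a step of a number 3 percentage points higher from compound 3 to compound 4 (within the scatter) in this assay that is not expected to exceed the scatter. Compound 4 is therefore estimated at 88%, with a range from 72% to 97%.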

Compound 4, a percentage reported as inhibition, at one concentration (the size of the read-out at that concentration, not a potency): 93%
Estimate against measurement, compound 4: 5 percentage points below, and the stated range covers the measured number.
By their numbers in this assay, from the lowest: compounds 3, 2, 4 and 1 (each within the scatter of the next).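

In this assay, 3-methoxyphenyl brings an oxygen atom that none of the other aryl groups on this sulfonyl sulfur carries, and 1 hydrogen-bond acceptor against 0 for 3-fluoro-4-methylphenyl, yet that exchange amounts only to a number 8 percentage points higher from compound 3 to compound 4 (within the scatter). Methoxy in place of chloro on an aromatic carbon gives a number 1 percentage points higher from compound 2 to compound 4 (within the scatter), and the comparison with the difluorinated aryl group gives a number 1 percentage points lower from compound 1 to compound 4 (within the scatter), so the number stays level with an oxygen-linked substituent as with halogens and a methyl group at this position, without any step leaving the scatter, and the four compounds cannot be ranked. Nothing available explains these numbers or accounts for the lack of separation among them.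

Because every compound was read at a single concentration, the read-out leaves open whether the four compounds would differ in potency across a full concentration range. It also leaves open whether a more drastic group on the sulfonyl sulfur, such as an aryl ring bearing a carboxylic acid or an amine, or a saturated cyclohexyl ring in place of the aryl ring, would move the number beyond the scatter.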